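The source may hold more compounds than are shown below. What is called first, only, known or untested is meant among the compounds shown, and "the series" means these compounds.

In a functional assay on MDA-MB-435 cells (Homo sapiens) for cytotoxicity, read by MTT assay, with a stated time of 72 h (on this read-out lower numbers stand for stronger inhibition and higher numbers for weaker inhibition), compound 1 `N[C@H]1CC[C@H](Nc2c(C(=O)NCc3ccc(F)cc3)nc(N3CCCCS3(=O)=O)c3cccnc23)CC1` gives 5000 nM and compound 2 `N[C@H]1CC[C@H](Nc2c(C(=O)NCc3ccc(F)cc3)nc(Br)c3cccnc23)CC1` gives 6000 nM. For the measured compounds named here, these two values lie within the usual scatter of each other, so compound 2 cannot be ranked against compound 1, the only other compound measured so far. Compound 3 `N[C@H]1CC[C@H](Nc2c(C(=O)NCc3ccc(F)cc3)nc(N3CCCCC3)c3cccnc23)CC1` is still unmeasured. It differs from compound 2 in one place: piperidin-1-yl in place of bromo on an aromatic carbon. In words, piperidin-1-yl stands in place of bromo on an aromatic carbon, next to the ring nitrogen. Going by the values given here, the one measured step that bears on this is a 1.2-fold higher number from compound 1 to compound 2 (0.08 log units; within the scatter), where bromine replaces a different six-membered non-aromatic ring on that same carbon, and it stays within the scatter. No change beyond the scatter is therefore expected in this assay. The expected step is a 1.2-fold lower number from compound 2 to compound 3 (0.08 log units; within the scatter). For compound 3 the estimated value is 5000 nM, with an expected range from 2000 nM to 12000 nM.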

Compound 3, half-maximal inhibitory concentration: 5000 nM
Beside the measured number, compound 3's estimate shows no gap at the digits printed; the range from low to high includes it.
By their numbers in this assay, from the lowest: compounds 1, 3 and 2 (each within the scatter of the next).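

In this assay, piperidin-1-yl in place of bromo on this aromatic carbon gives a 1.2-fold lower number from compound 2 to compound 3 (0.08 log units; within the scatter), and exchanging the sulfur-containing ring for piperidin-1-yl at the same carbon gives no change at the digits printed from compound 1 to compound 3 (within the scatter). For the compounds shown here, this carbon has now carried a single bromine atom and two different six-membered non-aromatic rings, and no step among the three compounds leaves the scatter, so adding a second ring shows that losing the sulfur and its two oxygens also leaves the number unchanged within the scatter. No measurement is available that would explain this flat result.

The compounds shown leave open whether a small primary amine, a carboxylic acid or a longer alkyl chain on this carbon would move the number beyond the scatter. They also leave open how changes to the (4-aminocyclohexyl)amino group would read in this assay.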